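Swapping a methyl for a methylsulfonyl on a shared core

The source may report more compounds than this note shows. Statements on the series, on what has been measured and on what is new or still open speak of the compounds shown alone.

Compound 1 has the structure `Cc1ccc(-c2csc(N3N=C(c4ccc(C)s4)CC3c3ccc(F)cc3)n2)cc1`. It was tested in a functional assay on A549 cells (Homo sapiens) for antiproliferative activity, read by XTT assay, with a stated time of 24 h; a higher number here means a weaker inhibitor, a lower number a stronger inhibitor. In this assay compound 1 gives > 500 ug/mL, which is a limit of the assay rather than a number. Compound 2, with the structure `O=[N+]([O-])c1ccc(-c2csc(N3N=C(c4ccc(Cl)s4)CC3c3ccc(F)cc3)n2)cc1`, belongs to the same series. In this assay compound 2 gives > 500 ug/mL, again a limit and not a number. So compound 1 stands at the limit of > 500 ug/mL in this assay, at which 2 of the 2 values shown sit, with no measured number to rank it against anything.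

Compound 3, with the structure `Cc1ccc(C2=NN(c3nc(-c4ccc(S(C)(=O)=O)cc4)cs3)C(c3ccc(F)cc3)C2)s1`, has not yet been tested. It differs from compound 1 in one place: methylsulfonyl in place of methyl on an aromatic carbon. Going by the values given here, no step between two measured compounds is available here, so nothing in the data says how large an effect this change has.

The step of an at least 1.2-fold lower number from compound 1 to compound 3 (0.09 log units; that floor lies within the scatter) is expected to be none beyond the usual scatter. Compound 3 is therefore estimated to give about 400 ug/mL in this assay, within a range from 150 ug/mL to 1000 ug/mL, with a good chance that only a limit is reported again.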

Compound 3, half-maximal inhibitory concentration: > 500 ug/mL
Compound 3 gave a limit, no number (the forecaster's own chance of this, stated with the estimate: 75%); at least 1.2-fold (0.09 log units) between middle value and limit.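

Compound 1 and compound 3 both end at a limit of the assay rather than a number, so no step between them can be read, and the same holds for every compound shown: the limit of > 500 ug/mL in this assay, at which 3 of the 3 values shown sit. The compounds shown leave open how strongly any of them acts on these cells, and whether methylsulfonyl in place of methyl changes that at all.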